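The source may hold more compounds than are shown below. What is called first, only, known or untested is meant among the compounds shown, and "the series" means these compounds.

Compound 1 `N=C(N)N/N=C(/C=C/c1ccccc1)c1ccccc1` gives 17000 nM
Compound 2 `N=C(N)N/N=C(/C=C/c1ccccc1F)c1ccccc1` gives 3900 nM
Compound 3 `N=C(N)N/N=C(/C=C/c1ccccc1Br)c1ccccc1` gives 4200 nM

In a functional assay on MCF7 cells (Homo sapiens) for antiproliferative activity, read by MTT assay, with a stated time of 48 h (a lower number here means a stronger inhibitor, a higher number a weaker inhibitor), compound 3 stands level with compound 2: the gap is a 1.1-fold higher number from compound 2 to compound 3 (0.03 log units; within the scatter) and so shows no real difference. Compound 1 has the highest number of the three, and the gap to it is a 4.0-fold lower number from compound 1 to compound 3 (0.61 log units; beyond the scatter) on this scale.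

Compound 4 `COc1ccccc1/C=C/C(=N/NC(=N)N)c1ccccc1` has not been measured yet. The change is methoxy in place of bromo on an aromatic carbon (methoxy in place of bromo on an aromatic carbon, ortho to a large group).

Two measured steps show what replacing hydrogen did: a 4.4-fold lower number from compound 1 to compound 2 (0.64 log units; beyond the scatter) with fluoro and a 4.0-fold lower number from compound 1 to compound 3 (0.61 log units; beyond the scatter) with bromo, both modest. The closest guide is the swap of fluoro for bromo, which gave a 1.1-fold higher number from compound 2 to compound 3 (0.03 log units; within the scatter) and thus nothing beyond the scatter. Among the measured compounds shown here, no methoxy compound has been measured here, so this guide is uncertain.

The expected result in this assay is no step beyond the scatter, with a 1.2-fold higher number from compound 3 to compound 4 (0.08 log units; within the scatter) as the estimated step. For compound 4 the estimate is 5000 nM with an expected range from 2000 nM to 13000 nM in this measurement.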

Compound 4, half-maximal inhibitory concentration: 7200 nM
Estimate against measurement, compound 4: 1.4-fold (0.16 log units) below; the measured number falls inside the stated range.
By their numbers in this assay, from the lowest: compounds 2, 3 and 4 (each within the scatter of the next); then compound 1.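

In this assay, among the compounds shown here, methoxy at this place, on an aromatic carbon ortho to a large group, brings in oxygen and a hydrogen-bond acceptor where the earlier compounds carried a single halogen atom, yet the reading stays level with both halogen compounds (a 1.7-fold higher number from compound 3 to compound 4 (0.23 log units; within the scatter); a 1.8-fold higher number from compound 2 to compound 4 (0.27 log units; within the scatter)). The position therefore tolerates a group with two heavy atoms as well as fluoro and bromo, and the methoxy compound still differs from the unsubstituted parent by more than the scatter (a 2.4-fold lower number from compound 1 to compound 4 (0.37 log units; beyond the scatter)), so all three groups shown give a lower number than hydrogen. Nothing available explains why these three groups read alike.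

Still open, from the compounds shown here alone, is whether this tolerance extends to quite different groups at the same place, such as an amine, a carboxylic acid or a longer ether chain. The compounds shown also leave open whether any group here can move the number well away from that of the halogen compounds.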